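A Small Swap on the Strongest of Three

The source may hold more compounds than are shown below. What is called first, only, known or untested is meant among the compounds shown, and "the series" means these compounds.

Of the compounds shown here, three sharing one core have been measured in a functional assay on SW-620 cells (Homo sapiens) for cytotoxicity; a higher number here means a weaker inhibitor, a lower number a stronger inhibitor. Compound 1 `CS(=O)(=O)c1ccc2nc(NC(=O)CCCCCCC(=O)NO)sc2c1` gives 5.42 ug/mL, compound 3 `Cc1ccc2nc(NC(=O)CCCCC(=O)NO)sc2c1` gives 4.69 ug/mL, and compound 2 `Cc1ccc2nc(NC(=O)CCCCCCC(=O)NO)sc2c1` gives 0.56 ug/mL. Compound 2 has the lowest number of the three, and its gaps to both others lie beyond the scatter, so it is the strongest inhibitor of this small set.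

Compound 4 `COc1ccc2nc(NC(=O)CCCCCCC(=O)NO)sc2c1` keeps the chain of compound 2 but carries methoxy in place of methyl on an aromatic carbon. The closest evidence comes from a change at that same carbon, methyl in place of methylsulfonyl, which gave a 9.7-fold lower number from compound 1 to compound 2 (0.99 log units; beyond the scatter). The other measured step, an 8.4-fold higher number from compound 2 to compound 3 (0.92 log units; beyond the scatter), changes the chain, which stays the same in compound 4, so it says little here. Among the compounds with values here, no methoxy compound has been measured yet, and a single step at this carbon sets no rule. Still, going from methyl to methoxy is a smaller structural change than going from methylsulfonyl to methyl. A modest shift is therefore expected in this assay, probably within the scatter and with only a weak lean towards a higher number: the estimated step is a 1.3-fold higher number from compound 2 to compound 4 (0.10 log units; within the scatter). For compound 4 the estimate is 0.7 ug/mL, with an expected range from 0.3 ug/mL to 1.8 ug/mL.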

Compound 4, half-maximal inhibitory concentration: 0.96 ug/mL
Compound 4: middle estimate off by 1.4-fold (0.14 log units), on the low side, within the range that was stated.
By their numbers in this assay, from the lowest: compounds 2 and 4 (each within the scatter of the next); then compounds 3 and 1 (each within the scatter of the next).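

In this assay, methoxy in place of methyl gives a 1.7-fold higher number from compound 2 to compound 4 (0.23 log units; within the scatter) and so cannot be told apart from methyl at this aromatic carbon, even though it brings one more heavy atom, an oxygen, and a hydrogen-bond acceptor that methyl lacks. Methoxy in place of methylsulfonyl gives a 5.6-fold lower number from compound 1 to compound 4 (0.75 log units; beyond the scatter) and so runs in the same direction as the earlier step with methyl in place of methylsulfonyl, which shows that the lower number is not tied to methyl alone, since two of the three groups seen at this carbon now sit well apart from methylsulfonyl. Nothing on hand says what sets methylsulfonyl apart from the other two groups here.

The compounds shown leave open how far this carbon stays so undemanding, since an amine, a carboxylic acid or a plain hydrogen there would test groups quite unlike the three seen so far. They also leave open whether methoxy would read the same way on the shorter chain of compound 3, or whether its match with methyl holds only on the longer chain shared by compound 2 and compound 4.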